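The source may hold more compounds than are shown below. What is called first, only, known or untested is meant among the compounds shown, and "the series" means these compounds.

Measured compounds:
Compound 1 `Oc1ccc(-c2cc(-c3cccc(F)c3)cc(-c3ccccc3O)n2)cc1` — in a functional assay on DU-145 cells (Homo sapiens) for inhibition (on this read-out higher numbers stand for weaker inhibition and lower numbers for stronger inhibition), compound 1 sits at the limit > 50000 nM.
Compound 2 `Oc1ccc(-c2cc(-c3cccc(F)c3)cc(-c3cccc(O)c3)n2)cc1` — in this assay compound 2 gives 2700 nM.
Compound 3 `Oc1cccc(-c2cc(-c3ccc(OC(F)(F)F)cc3)cc(-c3ccccc3O)n2)c1` — in this assay compound 3 gives 21100 nM.

Compound 1 and compound 2 differ in one place: 3-hydroxyphenyl in place of 2-hydroxyphenyl on an aromatic carbon. This change gave an at least 18-fold lower number from compound 1 to compound 2 (1.26 log units; beyond the scatter). The step is known only as a lower bound because the limit of > 50000 nM in this assay, at which 1 of the 3 values shown sits, is a limit of the assay rather than a number. Compound 3 has a different core from compound 1, and the difference between the two cores is not broken down here. Against compound 2, compound 3 stands with the higher of the two numbers.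

Compound 4 `Oc1cccc(-c2cc(-c3ccc(OC(F)(F)F)cc3)cc(-c3cccc(O)c3)n2)c1` is not yet measured. It is related to compound 3 by 3-hydroxyphenyl in place of 2-hydroxyphenyl on an aromatic carbon. The change is the same kind of change as that from compound 1 to compound 2, though the surroundings are not the same: in compound 1 the position is meta to a 3-fluorophenyl group and meta to a 4-hydroxyphenyl group, whereas in compound 3 it is meta to a 3-hydroxyphenyl group and meta to a large group. Because an at least 18-fold lower number from compound 1 to compound 2 (1.26 log units; beyond the scatter) was large, a step of similar direction is expected from compound 3 to compound 4, estimated as a 14-fold lower number from compound 3 to compound 4 (1.15 log units; beyond the scatter), with the earlier step only setting a floor. Compound 4 is accordingly expected to give about 1500 nM in this assay, most likely between 400 nM and 8000 nM.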

Compound 4, half-maximal inhibitory concentration: > 50000 nM
Compound 4 was reported as a limit (the forecaster's own chance of this, stated with the estimate: 5%); at least 33-fold (1.52 log units) between middle value and limit.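

In this assay the change of 2-hydroxyphenyl to 3-hydroxyphenyl did not carry over from one core to the other: it gave an at least 2.3-fold higher number from compound 3 to compound 4 (0.37 log units; beyond the scatter), the opposite direction to the earlier step, and the two steps differ clearly: the same change on two cores in this assay, an at least 18-fold lower number (1.26 log units; beyond the scatter) from compound 1 to compound 2 and an at least 2.3-fold higher number (0.37 log units; beyond the scatter) from compound 3 to compound 4, at least 43-fold (1.64 log units) apart, beyond the scatter of two such steps. From the compounds shown here alone, compound 4 gives a limit and not a number, as does compound 1, so each step is known only as a bound and the true gap between them stays unknown: the limit of > 50000 nM in this assay, at which 2 of the 4 values shown sit. The result shows that, in these two pairs, the effect of this change depends on the core that carries it, but it does not show which difference between the core of compound 1 and the core of compound 3 turns the step around, and two pairs establish no rule for the wider series.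

The compounds shown leave open whether the step would hold on a core that differs from the core of compound 1 in only one place, which could separate the part played by the 3-fluorophenyl group from that of the other groups. They also leave open how this assay would read with a methoxy group, an amine or a carboxylic acid in place of the hydroxyl on the ring that changes.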